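A few compounds are considered here, and "the series" means these few. Any claim that something is new, unique, unknown or untested is made for them only; others in the source may bear on it.

Compound 1 `CC1CC/C(=N\Nc2cccc(Br)c2)c2ncc(C(=O)O)c(=O)n21` stands lowest of the two numbers in a functional assay on the whole organism for inhibition, with Rattus norvegicus as the target (a higher number here means that more compound is needed for the effect, a lower number that less compound is needed), at 0.4 umol/kg. Its nearest neighbour, compound 2 `CC1CC/C(=N\Nc2ccc(O)cc2)c2ncc(C(=O)O)c(=O)n21`, gives 1.7 umol/kg in this assay; the step of a 4.3-fold higher number from compound 1 to compound 2 (0.63 log units; beyond the scatter) comes with 4-hydroxyphenyl in place of 3-bromophenyl on an amine nitrogen. Compound 3 `CC1CC/C(=N\Nc2cccc(C(=O)O)c2)c2ncc(C(=O)O)c(=O)n21` is the next member to be measured; it differs from compound 1 by carboxy in place of bromo on an aromatic carbon.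

Going by the values given here, only the step from compound 1 to compound 2 bears on this change: there, too, the bromo was lost and a hydrogen-bond donor and acceptor entered, and the number rose modestly. Carboxy in place of bromo is expected to behave in the same direction, with a step of about a 3.8-fold higher number from compound 1 to compound 3 (0.57 log units; beyond the scatter) in this assay. Compound 3 is therefore estimated at 1.5 umol/kg in this assay, within 0.5 umol/kg to 5 umol/kg.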

Compound 3, dose for 50% inhibition: 26.6 umol/kg
Estimate against measurement, compound 3: 18-fold (1.25 log units) below; measured number above the stated range.
By their numbers in this assay, from the lowest: compound 1; then compound 2; then compound 3.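

Carboxy in place of bromo gives a 67-fold higher number from compound 1 to compound 3 (1.82 log units; beyond the scatter) in this assay and so shows that this aromatic carbon is far from indifferent to the group it carries. The step is large, whereas a 4.3-fold higher number from compound 1 to compound 2 (0.63 log units; beyond the scatter) was modest, so losing bromo does not by itself fix the size of the rise, and the group that enters matters. No measurement on hand accounts for the size of this step.

The compounds shown leave open whether the rise belongs to carboxy in particular or would follow other groups on the same aromatic carbon. A methyl ester, a primary amide, a hydroxy or a chloro there would help to separate these readings.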